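The compounds below may be only part of what the source reports. "The series", "measured", "known", "first", "only" and "open" are said of these compounds alone.

Values so far in a functional assay on MDA-MB-231 cells (Homo sapiens) for antiproliferative activity, read by MTT assay; on this read-out higher numbers stand for weaker inhibition and lower numbers for stronger inhibition
- Compound 1 `CCCC/C=C\CCCCCCCCCc1cc(=O)c2c(O)cc(O)c(C)c2o1` gives 6790 nM
- Compound 2 `CCCCCCCCCCCCCCCC1(O)CC(=O)c2c(O)cc(O)cc2O1` gives 6790 nM
- Compound 3 `CC/C=C\C/C=C\C/C=C\CCCCCCCC1(O)CC(=O)c2c(O)cc(OCOC)cc2O1` gives 6790 nM

Compound 3 (6790 nM) stands level with compound 1 and compound 2, so all three lie within the scatter. Compound 4 `CCCC/C=C\CCCCCCCCCC1(O)CC(=O)c2c(O)cc(OCOC)cc2O1` is not yet measured. It differs from compound 3 by a group of 8 heavy atoms (8 carbon; no ring) in place of a group of 10 heavy atoms (10 carbon; no ring), on a saturated chain carbon, seven bonds along the chain from a saturated ring carbon (oct-3-en-1-yl in place of a group of 10 heavy atoms, on a saturated chain carbon, seven bonds along the chain from a saturated ring carbon). For the measured compounds named here, no step between measured compounds is available, but compound 1, compound 2 and compound 3 (6790 nM) share one value despite their structural differences. No change beyond the scatter is expected in this assay. The expected step is a 1.0-fold higher number from compound 3 to compound 4 (0.00 log units; within the scatter) (an estimate). Compound 4 is estimated at 6800 nM (expected range 3200 nM to 14000 nM).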

Compound 4, half-maximal inhibitory concentration: 42800 nM
Compound 4: the middle estimate sits 6.3-fold (0.80 log units) below what was measured, and the stated range ends below it.
By their numbers in this assay, from the lowest: compounds 1, 2 and 3 (each within the scatter of the next); then compound 4.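

Across this assay, the chain carbon seven bonds along from a saturated ring carbon proves sensitive: oct-3-en-1-yl in place of the group with no common name gives a 6.3-fold higher number from compound 3 to compound 4 (0.80 log units; beyond the scatter). The earlier compounds shown here offered no step at this position, so their shared value said nothing about it. No supporting data bear on the cause of this step.

The two groups differ in both carbon count and double bonds, and these remain unseparated. As far as these compounds go, how a saturated octyl group, a longer chain or a carboxylic acid here would read remains open.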